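Working notes: diketopiperazine-type series, cytotoxicity, step 3 to 4

This account rests on a few compounds, and the source may have more. Where it says the series, first, only, none or still open, it means among the compounds named here.

Measured so far:
- compound 1 `C=CCn1c(=O)/c(=C\c2ccc(Cl)c(Cl)c2)[nH]c(=O)/c1=C\c1ccccc1OC`: "not active" (no number reported)
- compound 2 `C=CCn1c(=O)/c(=C\c2ccccc2OC)[nH]c(=O)/c1=C\c1ccccc1OC`: 6900 nM
- compound 3 `C=CCn1c(=O)/c(=C\c2ccc(F)c(Br)c2)[nH]c(=O)/c1=C\c1ccccc1OC`: "not active" (no number reported)

All three share one core and differ only in the aryl group on the double-bonded chain carbon. Among the compounds with values here, in a functional assay on HeLa cells (Homo sapiens) for cytotoxicity, read by CCK-8 assay, with a stated time of 72 h (a lower number here means a stronger inhibitor, a higher number a weaker inhibitor), compound 2 gives 6900 nM, and it is the only member with a numerical result. Compound 1 is reported as "not active" (no number reported) in this assay. Within the data shown here, compound 3 stands with it: in this assay compound 3 is reported as "not active" (no number reported), so no number is available and no step from compound 3 to any measured neighbour can be sized.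

The next compound, compound 4 `C=CCn1c(=O)/c(=C\c2cccc(C)c2)[nH]c(=O)/c1=C\c1ccccc1OC`, is not yet measured. It differs from compound 3 by 3-methylphenyl in place of 3-bromo-4-fluorophenyl on a double-bonded chain carbon bound to an aromatic carbon. Among the measured compounds shown here, with no measured step touching compound 3 and two of three members reported without a number, the expected outcome in this assay is weak or absent activity; direction and size of the move from compound 3 cannot be stated beyond saying that a result at or beyond the weak end is more likely than a clear gain.

Compound 4 is estimated at 12000 nM in this assay, with an expected range of 4000 nM to 40000 nM, and a substantial chance that only a no-activity report is returned.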

Compound 4, half-maximal inhibitory concentration: 19300 nM
For compound 4 the middle estimate is 1.6-fold (0.21 log units) below the measured one; measured number inside the range.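

In this assay the place on the double-bonded chain carbon bound to an aromatic carbon now has a sized change: 3-methylphenyl in place of 2-methoxyphenyl gives a 2.8-fold higher number from compound 2 to compound 4 (0.45 log units; beyond the scatter) and so a modest loss, beyond the scatter. Compound 4 at 19300 nM also shows that a numerical result at this place is not confined to 2-methoxyphenyl, while the 3-bromo-4-fluorophenyl of compound 3 and the dichlorophenyl of compound 1 carry only a no-activity report, so the steps touching those two compounds cannot be read. Nothing measured here accounts for the change in number between these aryl groups.

With only two numbers at this place, the compounds shown do not separate the effect of the methoxy group from that of where the substituent sits on the phenyl ring. Also open, as far as these compounds go, is how this assay responds when the aryl group carries an amine or a carboxylic acid, and whether any such group could bring the number below that of compound 2 at 6900 nM in this assay.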